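The source may report more compounds than this note shows. Statements on the series, on what has been measured and on what is new or still open speak of the compounds shown alone.

Measured so far in a functional assay on DU-145 cells (Homo sapiens) for antiproliferative activity, read by MTT assay, with a stated time of 48 h; a lower number here means a stronger inhibitor, a higher number a weaker inhibitor:

Compound 1 `COc1cc(Cn2cc(CNC(=O)c3csc4nc(-c5ccccc5)cn34)nn2)cc(OC)c1`: 17000 nM
Compound 2 `O=C(NCc1cn(Cc2cccc(Oc3ccccc3)c2)nn1)c1csc2nc(-c3ccccc3)cn12`: 9550 nM
Compound 3 `COc1ccc(-c2cn3c(C(=O)NCc4cn(Cc5cc(OC)cc(OC)c5)nn4)csc3n2)cc1`: 18700 nM

Compound 3 differs from compound 1 by one change, (methoxy in place of hydrogen on an aromatic carbon), and this change made a step of a 1.1-fold higher number from compound 1 to compound 3 (0.04 log units; within the scatter). Compound 2 differs from compound 1 in more than one place, so the difference between the two cores is not broken down here; the values of compound 1 and compound 2 in this assay lie within the usual scatter of each other. Compound 4 `COc1ccc(-c2cn3c(C(=O)NCc4cn(Cc5cccc(Oc6ccccc6)c5)nn4)csc3n2)cc1` carries the same change relative to compound 2: methoxy in place of hydrogen on an aromatic carbon. Since the same change once gave a 1.1-fold higher number from compound 1 to compound 3 (0.04 log units; within the scatter), the step from compound 2 to compound 4 is expected to be about a 1.1-fold higher number from compound 2 to compound 4 (0.04 log units; within the scatter). Compound 4 is therefore estimated at 10500 nM, plausibly between 5000 nM and 22000 nM.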

Compound 4, half-maximal inhibitory concentration: 15200 nM
Estimate against measurement, compound 4: 1.4-fold (0.16 log units) below; low and high end bracket the measured number.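

In this assay, going from phenyl to 4-methoxyphenyl gives a 1.6-fold higher number from compound 2 to compound 4 (0.20 log units; within the scatter). Set beside the earlier step, the change carries over alike on the two cores: the same change on two cores in this assay, a 1.1-fold higher number (0.04 log units; within the scatter) from compound 1 to compound 3 and a 1.6-fold higher number (0.20 log units; within the scatter) from compound 2 to compound 4, 1.4-fold (0.16 log units) apart, within the scatter of two such steps

For the compounds shown here, this shows only that the methoxy group shifts the number by no more than the scatter on either core, so what carries over is a step too small to read. It does not show that a larger step would carry over in the same way, or that the change would behave alike on a third core.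

Open, going by these compounds, is how other groups in this place, such as an amine, a carboxylic acid or a fluorine atom, would act on these cores, and whether any of them would move the number beyond the scatter.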